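A few compounds are considered here, and "the series" means these few. Any claim that something is new, unique, unknown or untested is made for them only; others in the source may bear on it.

Of the compounds shown here, three have been measured in a functional assay on HCC1806 cells (Homo sapiens) for inhibition, read by sulforhodamine B assay, tested at 10 uM; a higher number here means more inhibition at the concentration tested (going by the name of the read-out), a lower number less inhibition: compound 1 `CN(C)c1ccc(C2CC(c3ccc(-n4cncn4)cc3)=NN2)cc1` gives 6.8%; compound 2 `CN(C)c1ccc(C2CC(c3ccc(-n4cncn4)cc3)=NN2C(=O)/C=C/c2ccccc2)cc1` gives -3.7%; compound 3 `CN(C)c1ccc(C2CC(c3ccc(-n4cncn4)cc3)=NN2S(=O)(=O)c2ccc(Br)cc2)cc1` gives 26.3%.

Compound 3 stands highest of the three, with a number 19.5 percentage points higher from compound 1 to compound 3 (beyond the scatter) and a number 30 percentage points higher from compound 2 to compound 3 (beyond the scatter), while a number 10.5 percentage points lower from compound 1 to compound 2 (beyond the scatter) runs the other way. Compound 4 `CN(C)c1ccc(C2CC(c3ccc(-n4cncn4)cc3)=NN2S(=O)(=O)c2ccc(C#N)cc2)cc1` differs from compound 3 by cyano in place of bromo on an aromatic carbon. Among the measured compounds shown here, no measured step touches this part of the molecule: all three steps concern the group on the ring nitrogen, so none bears directly on the change to compound 4. The expectation is therefore a step of a number 1.3 percentage points lower from compound 3 to compound 4 (within the scatter), which would not exceed the scatter. Compound 4 is expected to give 25%, in a range of 5% to 45%.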

Compound 4, a percentage reported as inhibition, at one concentration (the size of the read-out at that concentration, not a potency): 33.1%
Beside the measured number, compound 4's estimate is 8.1 percentage points below it, and the stated range covers the measured number.
By their numbers in this assay, from the lowest: compound 2; then compound 1; then compounds 3 and 4 (each within the scatter of the next).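

In this assay, cyano in place of bromo on the aromatic carbon gives a number 6.8 percentage points higher from compound 3 to compound 4 (within the scatter), so the two groups cannot be told apart at this position. Both (4-substituted phenyl)sulfonyl compounds now read clear of the other two, with a number 26.3 percentage points higher from compound 1 to compound 4 (beyond the scatter) and a number 36.8 percentage points higher from compound 2 to compound 4 (beyond the scatter). Nothing available explains these differences. As far as these compounds go, whether a methoxy group or an amine at this position would read the same remains open, as does how much of the step from compound 1 belongs to the sulfonyl link rather than its phenyl ring.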